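Swapping a Meta Substituent on the Aryl Amide

A few compounds are considered here, and "the series" means these few. Any claim that something is new, unique, unknown or untested is made for them only; others in the source may bear on it.

Compound 3 `O=C(Nc1c(C(O)(C(F)(F)F)C(F)(F)F)ccc2ccccc12)c1cccc(C(F)(F)F)c1` gives 84 nM in an assay on LtK cells with ATP-sensitive inward rectifier potassium channel 11 (Homo sapiens) as the target (a lower number here means that less compound is needed, a higher number that more compound is needed for the effect), the lowest of the three numbers. Compound 1 `O=C(CCc1ccccc1)Nc1c(C(O)(C(F)(F)F)C(F)(F)F)ccc2ccccc12` gives 1750 nM in this assay, and compound 2 `O=C(NCCCCCCCl)Nc1c(C(O)(C(F)(F)F)C(F)(F)F)ccc2ccccc12` gives 4840 nM; the steps of a 21-fold lower number from compound 1 to compound 3 (1.32 log units; beyond the scatter) and a 58-fold lower number from compound 2 to compound 3 (1.76 log units; beyond the scatter) are large, while a 2.8-fold higher number from compound 1 to compound 2 (0.44 log units; beyond the scatter) is modest. Compound 4 `O=C(Nc1c(C(O)(C(F)(F)F)C(F)(F)F)ccc2ccccc12)c1cccc([N+](=O)[O-])c1` keeps the aryl amide and differs only by nitro in place of trifluoromethyl on an aromatic carbon. Within the data shown here, no measured step touches a substituent on that phenyl ring, so nothing directly bears on this change; the large gains on going to an aryl amide suggest that an aryl amide stays potent. The step of a 1.8-fold higher number from compound 3 to compound 4 (0.25 log units; within the scatter) is therefore expected to be small. For compound 4 an estimate of 150 nM in this assay is expected, within 40 nM to 600 nM.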

Compound 4, half-maximal effective concentration: 117 nM
Compound 4: middle estimate off by 1.3-fold (0.11 log units), on the high side, within the range that was stated.
By their numbers in this assay, from the lowest: compounds 3 and 4 (each within the scatter of the next); then compound 1; then compound 2.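

Nitro and trifluoromethyl are interchangeable on this aromatic carbon in this assay, with the step between them within the scatter (a 1.4-fold higher number from compound 3 to compound 4 (0.14 log units; within the scatter)); this is the first comparison of two substituents on that ring. The large gain of the aryl amide over the other two compounds also holds with 3-nitrophenyl (a 15-fold lower number from compound 1 to compound 4 (1.17 log units; beyond the scatter)) and (a 41-fold lower number from compound 2 to compound 4 (1.62 log units; beyond the scatter)), so it is not tied to trifluoromethyl. Nothing given here explains this result. As far as these compounds go, whether an amine, a carboxylic acid or plain hydrogen at this place would keep the number remains open.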